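Aryl substituent variation on a shared core in cell inhibition

A few compounds are considered here, and "the series" means these few. Any claim that something is new, unique, unknown or untested is made for them only; others in the source may bear on it.

The three measured compounds share one core and differ only at the aryl end of the hydrazone arm. In a functional assay on MDA-MB-231 cells (Homo sapiens) for inhibition, read by MTT assay, with a stated time of 24 h, tested at 100 uM (on this read-out higher numbers stand for more inhibition at the one concentration tested (going by the name of the read-out) and lower numbers for less inhibition), compound 1 `COc1ccc(/C=N/NC(=O)c2ccc(O[C@@H]3O[C@H](CO)[C@@H](O)[C@H](O)[C@H]3O)cc2)cc1` gives 11.3%, compound 2 `N#Cc1cccc(/C=N/NC(=O)c2ccc(O[C@@H]3O[C@H](CO)[C@@H](O)[C@H](O)[C@H]3O)cc2)c1` gives 6.17%, and compound 3 `O=C(N/N=C/c1cccc([N+](=O)[O-])c1)c1ccc(O[C@@H]2O[C@H](CO)[C@@H](O)[C@H](O)[C@H]2O)cc1` gives 6.23%. Compound 3 stands nearest compound 2 and furthest from compound 1, both gaps within the scatter: a number 0.1 percentage points higher from compound 2 to compound 3 (within the scatter) and a number 5.1 percentage points lower from compound 1 to compound 3 (within the scatter). Compound 4 `O=C(N/N=C/c1cccc(Cl)c1)c1ccc(O[C@@H]2O[C@H](CO)[C@@H](O)[C@H](O)[C@H]2O)cc1` differs from compound 3 by chloro in place of nitro on an aromatic carbon. Among the compounds with values here, the closest precedent, the swap of nitro for cyano, was flat, and the larger aryl exchange a number 5.1 percentage points lower from compound 1 to compound 2 (within the scatter) also stayed within the scatter. For compound 4 no step beyond the scatter is therefore expected in this assay, a number 0.8 percentage points higher from compound 3 to compound 4 (within the scatter). Compound 4 is estimated at 7%, in the range 0% to 17%.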

Compound 4, a percentage reported as inhibition, at one concentration (the size of the read-out at that concentration, not a potency): 5.02%
The estimate for compound 4 lay 2 percentage points above the measured number, and the stated range covers the measured number.
By their numbers in this assay, from the lowest: compounds 4, 2, 3 and 1 (each within the scatter of the next).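

In the working notes on this position, chloro on the aromatic carbon meta to a large group joins nitro and cyano as a third substituent there, and in this assay neither exchange leaves the scatter (a number 1.2 percentage points lower from compound 3 to compound 4 (within the scatter); a number 1.2 percentage points lower from compound 2 to compound 4 (within the scatter)). One heavy atom in place of three at this carbon therefore leaves the read-out unresolved, as does the wider exchange of 3-chlorophenyl for 4-methoxyphenyl (a number 6.3 percentage points lower from compound 1 to compound 4 (within the scatter)). No measurement bears on why these groups read alike.

Open, going by these compounds, is whether an amine or a carboxylic acid on this aromatic carbon would give a step beyond the scatter.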